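Chain branching in the thioether series: compound 3 to compound 4

A few compounds are considered here, and "the series" means these few. Any claim that something is new, unique, unknown or untested is made for them only; others in the source may bear on it.

Measured so far:
compound 1 `Cc1cccc(C#CCSc2cccc(Cl)c2)n1` — 43 nM
compound 2 `Cc1cccc(C#CCN(C)c2ccccc2)n1` — 6730 nM
compound 3 `Cc1cccc(C#CC(C)Sc2cccc(Cl)c2)n1` — 118 nM

Compound 3 `Cc1cccc(C#CC(C)Sc2cccc(Cl)c2)n1` gives 118 nM in a functional assay for inhibition of metabotropic glutamate receptor 5 (Homo sapiens), read by FLIPR and calcium flux (a lower number here means a stronger inhibitor, a higher number a weaker inhibitor), and stands second highest of the three numbers. Its nearest neighbour is compound 1, and the gap is the step of a 2.7-fold higher number from compound 1 to compound 3 (0.44 log units; beyond the scatter). Compound 2 is the furthest away; its value in this assay shows a much higher number than compound 3, and the two differ in more than one place, so only the two values themselves can be compared.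

Compound 4 `CCC(C#Cc1cccc(C)n1)Sc1cccc(Cl)c1` carries methyl in place of hydrogen on a saturated chain carbon, two bonds along the chain from a sulfur and a triple-bonded carbon. Among the measured compounds shown here, the only measured step that bears on this change is a 2.7-fold higher number from compound 1 to compound 3 (0.44 log units; beyond the scatter), the first methyl placed on the same chain carbon, which raised the number by a modest amount beyond the scatter. For the measured compounds named here, no measured pair shows what a second carbon at that position does. A further modest rise, or a step that stays within the scatter, is therefore the expectation for compound 4, not a fall.

Compound 4 is expected to give 220 nM in this assay, within 80 nM to 600 nM, meaning an estimated step of a 1.9-fold higher number from compound 3 to compound 4 (0.27 log units; within the scatter).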

Compound 4, half-maximal inhibitory concentration: 862 nM
Beside the measured number, compound 4's estimate is 3.9-fold (0.59 log units) below it; measured number above the stated range.
By their numbers in this assay, from the lowest: compound 1; then compound 3; then compound 4; then compound 2.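

In this assay, the methyl to ethyl change at this saturated chain carbon gives a 7.3-fold higher number from compound 3 to compound 4 (0.86 log units; beyond the scatter), a larger rise than the first added carbon produced in a 2.7-fold higher number from compound 1 to compound 3 (0.44 log units; beyond the scatter). The two steps add up to a 20-fold higher number from compound 1 to compound 4 (1.30 log units; beyond the scatter), so compound 1, compound 3 and compound 4 form a rising order with chain length at this position, and the second carbon adds more than the first; no compound among these three goes against that order. Nothing measured on this series accounts for the size of the second step or for why it exceeds the first.

The compounds shown leave open whether a propyl chain or a cyclopropyl group on this carbon would continue the rise, and whether a hydroxyl or an amine there would follow the same order as the carbon groups. Also open, from the compounds shown here alone, is whether branching at the matching chain carbon would act the same way on the core of compound 2 , which stands at 6730 nM and differs from the thioethers in more than one place.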